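This account rests on a few compounds, and the source may have more. Where it says the series, first, only, none or still open, it means among the compounds named here.

Series notes. Compound 1 `COc1cc(OC)c2c(=O)cc(-c3ccc(OCC(O)CO)cc3)oc2c1` and compound 2 `COc1cc(OC)c2c(=O)cc(-c3ccc(-c4ccc(F)nc4)cc3)oc2c1` share a core; in a functional assay (Homo sapiens) for antiproliferative activity, read by resazurin assay, with a stated time of 48 h, tested at 20 uM (a higher number here means a stronger effect of the compound at the concentration tested, a lower number a weaker effect), compound 1 gives 16% and compound 2 gives 19%. The step of a number 3 percentage points higher from compound 1 to compound 2 (within the scatter) is the only measured one. Compound 2 stands highest of the two numbers, with compound 1 nearest at a gap within the scatter, so no order can be claimed. Compound 3 `COc1cc(OC)c2c(=O)cc(-c3ccc(NCCN(C)C)cc3)oc2c1` differs from compound 2 by (2-(dimethylamino)ethyl)amino in place of 6-fluoropyridin-3-yl on an aromatic carbon. Going by the values given here, no measured step covers this change; the one step available lies within the scatter, so the expected step of a number 1 percentage points higher from compound 2 to compound 3 (within the scatter) is likewise none beyond the scatter. Compound 3 is estimated at 20%, between 5% and 40%.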

Compound 3, a percentage reported as inhibition, at one concentration (the size of the read-out at that concentration, not a potency): 84%
Beside the measured number, compound 3's estimate is 64 percentage points below it, and the stated range ends below it.
By their numbers in this assay, from the lowest: compounds 1 and 2 (each within the scatter of the next); then compound 3.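

In this assay, the position on the six-membered aromatic ring of carbon only, para to a large group, proves responsive to the substituent: the change to (2-(dimethylamino)ethyl)amino gives a number 65 percentage points higher from compound 2 to compound 3 (beyond the scatter), and in place of 2,3-dihydroxypropoxy it gives a number 68 percentage points higher from compound 1 to compound 3 (beyond the scatter). The earlier pair, despite their different groups, showed no step beyond the scatter. Nothing at hand explains the size of this change.

Which part of the new chain carries the step stays open. A longer chain, a terminal morpholine or a terminal primary amine would separate chain length from the end group.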